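A Hydroxyphenyl Amide Tested in the Writhing Assay

The source may hold more compounds than are shown below. What is called first, only, known or untested is meant among the compounds shown, and "the series" means these compounds.

Compound 1 `O=C(/N=C1\NC2(CCCCO2)CCS1)c1ccc(F)cc1` gives 8.8 mg/kg; 28 mg/kg; 49 mg/kg (3 entries) in a functional assay on the whole organism (strain CF-1) with Mus musculus as the target, in the writhing test, with a stated time of 15 min; a higher number here means that more compound is needed for the effect, a lower number that less compound is needed.
Compound 2 `O=C(/N=C1\NC2(CCCCO2)CCS1)c1ccccc1Cl` reaches only the limit > 200 mg/kg in this assay.
Compound 3 `CC1(C(=O)/N=C2\NC3(CCCCO3)CCS2)CCCCC1` likewise reaches only the limit > 200 mg/kg in this assay.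

Compound 3 therefore has no number of its own; it sits at the limit, as do most of the values seen so far (the limit of > 200 mg/kg in this assay, at which 2 of the 3 values shown sit). The step that the two limits leave unreadable from compound 2 to compound 3 cannot be read for the same reason. The next compound, compound 4 `O=C(/N=C1\NC2(CCCCO2)CCS1)c1ccccc1O`, differs from compound 3 in one place: 2-hydroxyphenyl in place of 1-methylcyclohexyl on a carbonyl carbon. No measured step carries a 2-hydroxyphenyl group, so nothing shown bears directly on this change. The only numbered result belongs to compound 1, whose several entries the several entries of compound 1 in this assay, 8.8 mg/kg; 28 mg/kg; 49 mg/kg (3 entries) show a wide spread, while the 2-chlorophenyl analogue compound 2 stays at the limit. On this thin basis compound 4 is expected to land somewhere between those outcomes, with a fair chance of another limit; the estimated step of an at least 2.5-fold lower number from compound 3 to compound 4 (0.39 log units; beyond the scatter) is therefore uncertain. The expected value for compound 4 is 80 mg/kg, within a range from 15 mg/kg to 200 mg/kg.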

Compound 4, dose for half-maximal effect: > 200 mg/kg
Compound 4: a limit, no number; the forecaster's own chance of this, stated with the estimate: 55%; at least 2.5-fold (0.39 log units) between middle value and limit.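

Compound 4, like compound 2 and compound 3, stops at a limit in this assay instead of giving a number, so the steps among these three compounds cannot be read. The compounds shown leave open whether these three differ at all in the dose needed for the effect.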